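Thiol fragment and its deglycosylated analogue

A few compounds are considered here, and "the series" means these few. Any claim that something is new, unique, unknown or untested is made for them only; others in the source may bear on it.

Measured so far:
compound 1, `O=C(CCCCCN1C(=O)CC(SCCOCCOCCOc2cc(O)c(C(=O)CCc3ccc(O)cc3)c(O[C@@H]3O[C@H](CO)[C@@H](O)[C@H](O)[C@H]3O)c2)C1=O)OCn1cc(F)c(=O)[nH]c1=O`, in a functional assay on HT-29 cells (Homo sapiens) for cytotoxicity, read by sulforhodamine B assay, with a stated time of 48 h, in the presence of a further agent that is not named here (a higher number here means a weaker inhibitor, a lower number a stronger inhibitor), gives 93600 nM.
compound 2, `O=C(CCCSSCCOCCOCCOc1cc(O)c(C(=O)CCc2ccc(O)cc2)c(O[C@@H]2O[C@H](CO)[C@@H](O)[C@H](O)[C@H]2O)c1)OCn1cc(F)c(=O)[nH]c1=O`, in this assay gives 8000 nM.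
compound 3, `O=C(CCc1ccc(O)cc1)c1c(O)cc(OCCOCCOCCS)cc1O[C@@H]1O[C@H](CO)[C@@H](O)[C@H](O)[C@H]1O`, in this assay gives > 100000 nM.

For compound 3 the reading in this assay is only a limit, not a number; compound 3 therefore stands at the weak end of the three, where (the limit of > 100000 nM in this assay, at which 1 of the 3 values shown sits). Compound 4, `O=C(CCc1ccc(O)cc1)c1c(O)cc(OCCOCCOCCS)cc1O`, differs from compound 3 by hydrogen in place of 3,4,5-trihydroxy-6-(hydroxymethyl)oxan-2-yl on an oxygen on an aromatic ring. Among the compounds with values here, no measured pair covers this change, so the step is expected to be none beyond the scatter and to leave compound 4 at the same limit. Compound 4 is thus estimated at 100000 nM, within 30000 nM to 300000 nM, an expected step of a number no higher from compound 3 to compound 4 (the limit leaves the size open).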

Compound 4, half-maximal inhibitory concentration: 24200 nM
For compound 4 the middle estimate is 4.1-fold (0.62 log units) above the measured one; measured number outside the range, below it.
By their numbers in this assay, from the lowest: compound 2; then compound 4; then compound 1. At a limit, above all of these: compound 3.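

In this assay, hydrogen in place of 3,4,5-trihydroxy-6-(hydroxymethyl)oxan-2-yl on an oxygen on an aromatic ring gives an at least 4.1-fold lower number from compound 3 to compound 4 (0.61 log units; beyond the scatter), the first change measured at this position. The thiol fragment therefore keeps a measurable effect without this group, and the group's presence does not help in this pair. Compound 3 is held at a limit, so the true size of the step stays unknown: the limit of > 100000 nM in this assay, at which 1 of the 4 values shown sits.

On these data alone, whether the same change carries over to compound 1 and compound 2 remains open. Also open, as far as these compounds go, is how a methyl group on this oxygen would read.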